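The compounds below may be only part of what the source reports. "The series", "measured", "known", "first", "only" and "open" are said of these compounds alone.

Measured in a functional assay on PC-3 cells (Homo sapiens) for cytotoxicity, read by MTT assay, with a stated time of 72 h; a lower number here means a stronger inhibitor, a higher number a weaker inhibitor:

- Compound 1 `CC1=C(/C=C/C(=O)/C=C/c2ccc(C(F)(F)F)cc2)C(C)(C)CCC1`: 12000 nM
- Compound 2 `CC1=C(/C=C/C(=O)/C=C/c2ccccc2)C(C)(C)CCC1O`: 15500 nM
- Compound 3 `CC1=C(/C=C/C(=O)/C=C/c2cccc(C(F)(F)F)c2)C(C)(C)CCC1O`: 3500 nM

Compound 2 lies within the scatter of compound 1, while compound 3 lies clearly lower. Compound 4 `CC1=C(/C=C/C(=O)/C=C/c2ccc(C(F)(F)F)cc2)C(C)(C)CCC1O` differs from compound 2 by trifluoromethyl in place of hydrogen on an aromatic carbon, para to a large group. Going by the values given here, one measured step bears on this change, a 4.4-fold lower number from compound 2 to compound 3 (0.65 log units; beyond the scatter), which puts the same group on a different aromatic carbon. That step is modest, and its size carries over only loosely to the new place. A somewhat smaller drop in this assay is therefore expected. The expected step is a 2.4-fold lower number from compound 2 to compound 4 (0.38 log units; beyond the scatter). Compound 4 is estimated at 6500 nM, with an expected range from 2500 nM to 15000 nM.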

Compound 4, half-maximal inhibitory concentration: 10200 nM
Compound 4: middle estimate off by 1.6-fold (0.20 log units), on the low side, within the range that was stated.
By their numbers in this assay, from the lowest: compound 3; then compounds 4, 1 and 2 (each within the scatter of the next).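

In this assay, trifluoromethyl on this aromatic carbon, para to a large group, gives a 1.5-fold lower number from compound 2 to compound 4 (0.18 log units; within the scatter) and so does not repeat the step beyond the scatter seen with the same group on a different aromatic carbon, a 4.4-fold lower number from compound 2 to compound 3 (0.65 log units; beyond the scatter). Hydroxy in place of hydrogen on a saturated ring carbon also stays within the scatter, with a 1.2-fold lower number from compound 1 to compound 4 (0.07 log units; within the scatter). No evidence is available to account for either result.

The compounds shown leave open whether a nitrile or a methoxy group at this place would give a step beyond the scatter. They also leave open how the hydroxy change reads with trifluoromethyl on the other aromatic carbon.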